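Lengthening the Side Chain of Compound 2

This account rests on a few compounds, and the source may have more. Where it says the series, first, only, none or still open, it means among the compounds named here.

In a functional assay on HCT-116 cells (Homo sapiens) for antiproliferative activity, read by MTT assay, with a stated time of 48 h (a lower number here means a stronger inhibitor, a higher number a weaker inhibitor), compound 1 `CCC(CCO)n1cnc2c(Cl)nc(F)nc21` gives 18900 nM. Compound 2 `CCC(CCO)n1cnc2c(Cl)ncnc21` stands at > 50000 nM, which is a limit and not a number. Compound 3 `CCCCC(CCO)n1cnc2c(OC)ncnc21` reads > 50000 nM, also a limit. The series thus has two of its values at the limit of > 50000 nM in this assay, at which 2 of the 3 values shown sit. Compound 4 `CCCCCCC(CCO)n1cnc2c(Cl)ncnc21` follows from compound 2 through (butyl in place of hydrogen on a saturated chain carbon, three bonds along the chain from an aromatic nitrogen), with butyl in place of hydrogen on a saturated chain carbon. Among the measured compounds shown here, the only measured step is an at least 2.6-fold higher number from compound 1 to compound 2 (0.42 log units; beyond the scatter), with hydrogen in place of fluoro on an aromatic carbon. For the measured compounds named here, it is a different change, and no measured step alters this chain alone. A modest move toward a lower number is therefore expected in this assay, stated as an at least 1.7-fold lower number from compound 2 to compound 4 (0.25 log units; that floor lies within the scatter). Compound 4 is estimated at 28000 nM, with an expected range of 9000 nM to 50000 nM.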

Compound 4, half-maximal inhibitory concentration: 11900 nM
Beside the measured number, compound 4's estimate is 2.4-fold (0.37 log units) above it; low and high end bracket the measured number.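

Butyl in place of hydrogen on this saturated chain carbon gives an at least 4.2-fold lower number from compound 2 to compound 4 (0.62 log units; beyond the scatter) in this assay, so this place in the side chain, which no earlier step touched, does bear on the read-out. The step gives only a floor for the change, because compound 2 stands at a limit: the limit of > 50000 nM in this assay, at which 2 of the 4 values shown sit.

From the compounds shown here alone, whether a longer chain than butyl, or an amine on this carbon, would lower the number further stays open. So does whether butyl acts the same way alongside the fluoro group of compound 1.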